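Compound 3 and a bromo addition on its ring

The compounds below may be only part of what the source reports. "The series", "measured", "known", "first", "only" and "open" are said of these compounds alone.

Values in a functional assay on MDA-MB-231 cells (Homo sapiens) for antiproliferative activity, read by MTT assay, with a stated time of 72 h (a lower number here means a stronger inhibitor, a higher number a weaker inhibitor), are as follows.
Compound 1 `CCNC(=O)CCc1cccc2c1B(O)OC2` gives > 100000 nM as a limit of the assay, not a number.
Compound 2 `O=C(CCc1cccc2c1B(O)OC2)Nc1ccc(F)cc1` gives 440 nM as a measured number.
Compound 3 `Cc1ccc(NC(=O)CCc2cccc3c2B(O)OC3)cc1` gives 1100 nM as a measured number.

Of the two measured numbers, compound 3 holds the higher one. The gap is a 2.5-fold higher number from compound 2 to compound 3 (0.40 log units; beyond the scatter) and counts as modest. Compound 4 `Cc1ccc(NC(=O)CCc2cccc3c2B(O)OC3)cc1Br` differs by bromo in place of hydrogen on an aromatic carbon in one place: bromo in place of hydrogen on an aromatic carbon, ortho to a methyl group and meta to a large group.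

The large steps of an at least 220-fold lower number from compound 1 to compound 2 (2.35 log units; beyond the scatter) and an at least 90-fold lower number from compound 1 to compound 3 (1.95 log units; beyond the scatter) both replace ethyl on an amide-type nitrogen, so they bear little on a change at an aromatic carbon. The closer precedent is the modest step between the two measured numbers, methyl in place of fluoro on an aromatic carbon. Going by the values given here, no measured compound carries bromo. Compound 2, with its fluoro, gives 440 nM and this leans the expected direction towards a lower number, though only weakly. The estimated change is a 1.8-fold lower number from compound 3 to compound 4 (0.26 log units; within the scatter) and is expected to stay modest in size. Compound 4 is expected at 600 nM with a range of 200 nM to 1800 nM as the estimate.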

Compound 4, half-maximal inhibitory concentration: 870 nM
Beside the measured number, compound 4's estimate is 1.5-fold (0.16 log units) below it; low and high end bracket the measured number.
By their numbers in this assay, from the lowest: compounds 2, 4 and 3 (each within the scatter of the next, the first and the last beyond it). At a limit, above all of these: compound 1.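

In this assay, bromo in place of hydrogen on an aromatic carbon, ortho to a methyl group and meta to a large group, gives a 1.3-fold lower number from compound 3 to compound 4 (0.10 log units; within the scatter), so the two numbers cannot be told apart. The earlier aromatic change, a 2.5-fold higher number from compound 2 to compound 3 (0.40 log units; beyond the scatter), replaced one group with another, whereas this step adds one bromine to a carbon that carried hydrogen and leaves the activity within the scatter, so at this position the series accepts that added heavy atom without a readable change in this read-out. Nothing in the evidence at hand bears on why this step is so small.

Going by these compounds, whether the same carbon accepts other groups, such as an amine, a carboxylic acid or a methoxy group, remains open, as does whether bromo gives a similarly small step when added to the fluoro compound, compound 2. Also open is whether a longer chain linking the core to the amide carbonyl would keep the activity in this range, since every compound shown carries the same chain.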